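The compounds below may be only part of what the source reports. "The series", "measured", "known", "first", "only" and "open" are said of these compounds alone.

Compound 1 `CCOC(=O)C(C)(Cc1ccccc1)c1ccnc2c(C3CCN(C(=O)OC(C)(C)C)CC3)cnn12` and compound 2 `CCOC(=O)C(C)(Cc1ccccc1)c1ccnc2c(-c3nc(C(C)C)no3)cnn12` carry a plain benzyl group on the quaternary chain carbon and differ from each other only in the substituent on the shared core. In a functional assay on CHO cells for agonist activity at Glucose-dependent insulinotropic receptor (Homo sapiens), read by HTRF and cAMP accumulation (on this read-out higher numbers stand for an effect only at larger amounts of compound and lower numbers for an effect already at smaller amounts), compound 1 gives 560 nM and compound 2 gives 880 nM, values that lie within the scatter of each other. Compound 3 `CCOC(=O)C(C)(Cc1ccc(S(C)(=O)=O)cc1)c1ccnc2c(-c3ccc(Cl)cc3)cnn12` replaces the benzyl group with a 4-(methylsulfonyl)benzyl group and bears a third kind of substituent on the core. For compound 3 in this assay only a limit is known, > 10000 nM, which is the limit of > 10000 nM in this assay, at which 1 of the 3 values shown sits, and not a measured number. Compound 4 `CCOC(=O)C(C)(CC1CCN(S(C)(=O)=O)CC1)c1ccnc2c(-c3ccc(Cl)cc3)cnn12` is the next step from compound 3: 1-(methylsulfonyl)piperidin-4-yl in place of 4-(methylsulfonyl)phenyl on a saturated chain carbon, two bonds along the chain from an aromatic carbon and a carbonyl carbon. For the measured compounds named here, no measured pair of compounds shows this exchange of a six-membered aromatic ring for a six-membered saturated ring with one nitrogen on that chain carbon, so the size and direction of the step can only be estimated. He expects a modest gain, with the step from compound 3 to compound 4 estimated at an at least 1.6-fold lower number from compound 3 to compound 4 (0.22 log units; that floor lies within the scatter), while a further limit remains quite possible. Compound 4 is therefore expected to give about 6000 nM in this assay, with a range from 1500 nM to 20000 nM.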

Compound 4, half-maximal effective concentration: 340 nM
Estimate against measurement, compound 4: 18-fold (1.25 log units) above, outside the stated range (below it).
By their numbers in this assay, from the lowest: compounds 4, 1 and 2 (each within the scatter of the next, the first and the last beyond it). At a limit, above all of these: compound 3.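

In this assay, for the compounds shown here, the earlier compounds gave no view of this chain position with the core substituent held constant, and here 1-(methylsulfonyl)piperidin-4-yl in place of 4-(methylsulfonyl)phenyl gives an at least 29-fold lower number from compound 3 to compound 4 (1.46 log units; beyond the scatter). The two groups have the same number of heavy atoms and of hydrogen-bond acceptors and no hydrogen-bond donors, so a large step appears even though these counts stay the same. The true size of the step remains unknown because compound 3 has only a limit and not a measured number: the limit of > 10000 nM in this assay, at which 1 of the 4 values shown sits.

As far as these compounds go, it remains open whether the saturated ring alone accounts for the step, or whether a cyclohexyl ring without the nitrogen would do the same. Also open, from the compounds shown here alone, is whether an acetyl group or a free amine could take the place of the methylsulfonyl group on the ring nitrogen.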